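Swapping the Terminal Cation on a Collagen Promoter Inhibitor

A few compounds are considered here, and "the series" means these few. Any claim that something is new, unique, unknown or untested is made for them only; others in the source may bear on it.

Compound 1 `Cc1ccc(-n2cc(C(=O)Nc3cc(F)cc(F)c3)c(=O)c3ccc(N(C)C)nc32)cc1OCCCCCCC[N+]1(C)CCCC1` gives 12.7% in an assay on LX2 cells for inhibition of COL1A1 promoter (Homo sapiens), read by a luciferase reporter, with a stated time of 24 h, tested at 20 uM (on this read-out lower numbers stand for a weaker effect and higher numbers for a stronger effect at the one concentration tested), and stands lowest of the two numbers recorded. Compound 2 `CN(C)c1ccc2c(=O)c(C(=O)Nc3cc(F)cc(F)c3)cn(-c3ccc(Cl)c(OCCCCCCC[N+]4(C)CCCC4)c3)c2n1` gives 51% in this assay and compound 3 `CN(C)c1ccc2c(=O)c(C(=O)Nc3cc(F)cc(F)c3)cn(-c3ccc(OCCCCCCC[N+]4(C)CCCCC4)cc3F)c2n1` is reported in this assay as "not active" (no number reported) without a number. Within the data shown here, the only measured step is a number 38.3 percentage points higher from compound 1 to compound 2 (beyond the scatter) and it concerns an aromatic substituent, not the end of the chain. Compound 4 `Cc1ccc(-n2cc(C(=O)Nc3cc(F)cc(F)c3)c(=O)c3ccc(N(C)C)nc32)cc1OCCCCCCC[n+]1ccccc1` differs from compound 1 by a group of 6 heavy atoms (5 carbon, 1 nitrogen; one six-membered aromatic ring with 1 hetero atom) in place of a group of 6 heavy atoms (5 carbon, 1 nitrogen; one five-membered non-aromatic ring with 1 hetero atom), on a saturated chain carbon, seven bonds along the chain from an oxygen on an aromatic ring. Among the measured compounds shown here, no measured step bears on this exchange, so no shift beyond the scatter is expected, and compound 4 is estimated to give 13% in this assay with a range from 0% to 35%. The expected step of a number 0.3 percentage points higher from compound 1 to compound 4 (within the scatter) therefore lies within the scatter.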

Compound 4, a percentage reported as inhibition, at one concentration (the size of the read-out at that concentration, not a potency): 39.7%
The estimate for compound 4 lay 26.7 percentage points below the measured number, outside the stated range (above it).
By their numbers in this assay, from the lowest: compound 1; then compound 4; then compound 2.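

The end of the chain is not a silent position: in this assay, the one six-membered aromatic ring with 1 hetero atom in place of the one five-membered non-aromatic ring with 1 hetero atom gives a number 27 percentage points higher from compound 1 to compound 4 (beyond the scatter) while heavy-atom count and net charge stay the same. Among these compounds, the earlier step concerned an aromatic substituent, so this is the first measured sign that the terminal cation itself matters. From the compounds shown here alone, whether a trimethylammonium end group or a longer chain would shift the number further stays open, as does whether the exchange would act the same way on compound 2. No measurement at hand accounts for this step.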